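A few compounds are considered here, and "the series" means these few. Any claim that something is new, unique, unknown or untested is made for them only; others in the source may bear on it.

Compound 1 `CC(C)[C@H](NC(=O)COc1cccc2ccccc12)C(=O)N[C@@H](CC(=O)O)C(=O)COc1ccc(C(F)(F)F)cc1`: > 100000 nM in a functional assay on Jurkat cells (Homo sapiens); a lower number here means a stronger inhibitor, a higher number a weaker inhibitor; compound 2 `CC(=O)Nc1cccc(OCC(=O)[C@H](CC(=O)O)NC(=O)[C@@H](NC(=O)COc2cccc3ccccc23)C(C)C)c1`: > 100000 nM; compound 3 `CC(C)[C@H](NC(=O)COc1cccc2ccccc12)C(=O)N[C@@H](CC(=O)O)C(=O)COc1ccccc1F`: > 100000 nM.

Compound 1 gives > 100000 nM in this assay, and that value is a limit of the assay, not a number. Compound 2 gives > 100000 nM in this assay, again only a limit. Compound 3 gives > 100000 nM in this assay, once more a limit. So compound 3 stands nowhere readable among the three: all three values sit at the same limit (the limit of > 100000 nM in this assay, at which 3 of the 3 values shown sit), and every step between measured compounds is unreadable, a step that the two limits leave unreadable from compound 1 to compound 2, a step that the two limits leave unreadable from compound 1 to compound 3 and a step that the two limits leave unreadable from compound 2 to compound 3 alike.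

Compound 4 `CC(C)[C@H](NC(=O)COc1cccc2ccccc12)C(=O)N[C@@H](CC(=O)O)C(=O)COc1c(F)c(F)c(F)c(F)c1F` differs from compound 3 in one place: 2,3,4,5,6-pentafluorophenyl in place of 2-fluorophenyl on an oxygen on a saturated carbon. The measured steps that exchange the aryl group on this same oxygen on a saturated carbon bear on it, but none of them has a readable size. Nothing in the three measured compounds therefore supports expecting a step beyond the scatter; the expectation for the step that the limit leaves unreadable from compound 3 to compound 4 is that compound 4 also stays at the limit. Compound 4 is expected to give about 150000 nM in this assay, within 50000 nM to 500000 nM.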

Compound 4, half-maximal inhibitory concentration: 3050 nM
Compound 4: middle estimate off by 49-fold (1.69 log units), on the high side; measured number outside the range, below it.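

Compound 4 shows that this position can respond in this assay: with 2,3,4,5,6-pentafluorophenyl on the oxygen on a saturated carbon, the shared core gives an at least 32-fold lower number from compound 3 to compound 4 (1.51 log units; beyond the scatter), and the same group gives an at least 32-fold lower number from compound 2 to compound 4 (1.51 log units; beyond the scatter) and an at least 32-fold lower number from compound 1 to compound 4 (1.51 log units; beyond the scatter). None of the steps among the earlier compounds can be read, so until now no aryl exchange at this oxygen had shown any measurable response. A single change of aryl group now moves the value off the limit, while 2-fluorophenyl, 3-acetamidophenyl and 4-(trifluoromethyl)phenyl all leave the compound there: the limit of > 100000 nM in this assay, at which 3 of the 4 values shown sit.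

The compounds shown leave open whether all five fluorine atoms are needed, or whether a tetrafluorophenyl group would do the same, and whether a pentachlorophenyl group, with chlorine in place of fluorine, would match the pentafluorophenyl group. On these data alone, each of the three steps is only a minimum size, as the other end of each rests on a limit, so how far compound 4 truly stands from compound 1, compound 2 and compound 3 also remains open.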